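From Dioxolanylmethyl to Benzyl: Expecting Another Blank

The source may hold more compounds than are shown below. What is called first, only, known or untested is meant among the compounds shown, and "the series" means these compounds.

Compound 1 `COc1cccc(Cn2cc(-c3ccc(OC)c(OC)c3OC)nn2)c1` gives > 100000 nM in a functional assay on B16 cells (Mus musculus) for cytotoxicity, read by MTT assay, with a stated time of 48 h (on this read-out higher numbers stand for weaker inhibition and lower numbers for stronger inhibition), which is a limit of the assay rather than a number.
Compound 2 `COc1ccc(-c2cn(C[C@H]3COC(C)(C)O3)nn2)c(OC)c1OC` gives > 100000 nM in this assay, again only a limit.

Compound 2 thus stands at the limit of the assay, and (the limit of > 100000 nM in this assay, at which 2 of the 2 values shown sit), so no ordering of the two measured compounds is possible. Compound 3 `COc1ccc(-c2cn(Cc3ccccc3)nn2)c(OC)c1OC` differs from compound 2 by phenyl in place of 2,2-dimethyl-1,3-dioxolan-4-yl on a saturated chain carbon bound to an aromatic nitrogen. Among the measured compounds shown here, the one measured step, a step that the two limits leave unreadable from compound 1 to compound 2, also swaps the group on that carbon, yet it cannot be read, as both of its ends are limits. Compound 1 carries a 3-methoxyphenyl at that place, a close relative of the phenyl in compound 3, and it too sits at the limit. The expected step is therefore a step that the limit leaves unreadable from compound 2 to compound 3, nothing readable. Compound 3 is estimated at 150000 nM. Compound 3 is expected to fall between 40000 nM and 600000 nM, and most likely the assay will again report only its limit.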

Compound 3, half-maximal inhibitory concentration: 27500 nM
Compound 3: middle estimate off by 5.5-fold (0.74 log units), on the high side, outside the stated range (below it).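

Among the compounds shown here, compound 3 is the first compound here to give a measured number rather than a limit in this assay, so the group on the saturated chain carbon bound to an aromatic nitrogen can now be seen to matter. Phenyl in place of 2,2-dimethyl-1,3-dioxolan-4-yl gives an at least 3.6-fold lower number from compound 2 to compound 3 (0.56 log units; beyond the scatter), while hydrogen in place of methoxy on an aromatic carbon gives an at least 3.6-fold lower number from compound 1 to compound 3 (0.56 log units; beyond the scatter), so even that single methoxy separates two otherwise identical compounds. Both steps are minimum sizes, since compound 1 and compound 2 each rest on a limit: the limit of > 100000 nM in this assay, at which 2 of the 3 values shown sit.

For the compounds shown here, with only one measured number, it remains open whether a pyridine ring or a longer chain ending in an amine at this place would lower the number further. From the compounds shown here alone, how a fluorine on the phenyl ring would behave also remains open.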